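The source may report more compounds than this note shows. Statements on the series, on what has been measured and on what is new or still open speak of the compounds shown alone.

Compound 1 `Cc1ccccc1NS(=O)(=O)c1ccc(N2CCNC2=O)cc1`: 150 nM
Compound 2 `O=C1NCCN1c1ccc(S(=O)(=O)Nc2ccc(OC(F)F)cc2)cc1`: 410 nM
Compound 3 `COc1ccccc1NS(=O)(=O)c1ccc(N2CCNC2=O)cc1`: 300 nM

Of the compounds shown here, three built on one shared core have been tested in a functional assay on M21 cells (Homo sapiens) for antiproliferative activity, read by sulforhodamine B assay, with a stated time of 48 h; on this read-out lower numbers stand for stronger inhibition and higher numbers for weaker inhibition. Compound 1 gives the lowest of the three numbers. Its nearest neighbour is compound 3, separated by a 2.0-fold higher number from compound 1 to compound 3 (0.30 log units; within the scatter), a step that stays within the scatter. Compound 2, which carries a different aryl group on the sulfonamide nitrogen, gives the highest number of the three, and its gap to compound 1 lies beyond the scatter.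

Compound 4 `O=C1NCCN1c1ccc(S(=O)(=O)Nc2ccc(Br)cc2)cc1` has not yet been measured. It differs from compound 1 in one place: 4-bromophenyl in place of 2-methylphenyl on a sulfonamide nitrogen. Among the compounds with values here, only one measured step touches this position, the one from compound 1 to compound 3, and it changed a single substituent on the aromatic ring rather than exchanging the whole aryl group; its size was within the scatter. The change to compound 4 is larger in kind, and compound 2 shows that another aryl group on the same nitrogen can give a higher number than compound 1. On that basis a modest increase in this assay is expected, of about a 2.0-fold higher number from compound 1 to compound 4 (0.30 log units; within the scatter). Compound 4 is therefore estimated at 300 nM, with a range from 100 nM to 1000 nM.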

Compound 4, half-maximal inhibitory concentration: 130 nM
For compound 4 the middle estimate is 2.3-fold (0.36 log units) above the measured one; low and high end bracket the measured number.
By their numbers in this assay, from the lowest: compounds 4, 1, 3 and 2 (each within the scatter of the next, the first and the last beyond it).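

In this assay, compound 4 shows that the whole aryl group on the sulfonamide nitrogen can be exchanged without a change that can be read: 4-bromophenyl in place of 2-methylphenyl gives a 1.2-fold lower number from compound 1 to compound 4 (0.06 log units; within the scatter), so the two groups cannot be told apart here, although they differ in their substituent and in where it is named on the ring. Bromo in place of difluoromethoxy on an aromatic carbon gives a 3.2-fold lower number from compound 2 to compound 4 (0.50 log units; beyond the scatter), the first step in this set beyond the scatter that changes only a substituent on the aryl group, and it shows that this substituent can affect the number. The exchange of 2-methoxyphenyl for 4-bromophenyl gives a 2.3-fold lower number from compound 3 to compound 4 (0.36 log units; beyond the scatter), also beyond the scatter, so the aryl groups shown do not all give equivalent numbers.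

Nothing given here accounts for these differences. As far as these compounds go, it remains open how an amine or a carboxylic acid on the aryl ring, or a longer chain on the sulfonamide nitrogen in place of the aryl group, would fare in this assay.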